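The source may report more compounds than this note shows. Statements on the series, on what has been measured and on what is new or still open speak of the compounds shown alone.

Measured so far in a functional assay on HL-60 cells (Homo sapiens) for cytotoxicity, read by MTT assay, with a stated time of 4 days; a higher number here means a weaker inhibitor, a lower number a stronger inhibitor:
Compound 1 `Cc1ccc(S(=O)(=O)Oc2ccc3c(c2C)[C@H](Cn2cc(-c4ccc(C(F)(F)F)cc4)nn2)[C@@]24CC(=O)[C@@](C)(CC[C@@H]32)C4)cc1` – > 20000 nM, a limit of the assay.
Compound 2 `Cc1c(O)ccc2c1[C@H](Cn1cc(-c3ccc(C(F)(F)F)cc3)nn1)[C@@]13CC(=O)[C@@](C)(CC[C@@H]21)C3` – > 20000 nM, a limit of the assay.
Compound 3 `C=C1C(=O)[C@]23C[C@@]1(O)CC[C@H]2c1ccc(OS(=O)(=O)c2ccc(C)cc2)c(C)c1[C@@H]3Cn1cc(-c2ccc(Br)cc2)nn1` – 1020 nM.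

Compound 1 stands at the limit of > 20000 nM in this assay, at which 2 of the 3 values shown sit, so for compound 1 only a limit is known, not a number. Going by the values given here, the one single-point change within the measured set, hydrogen in place of (4-methylphenyl)sulfonyl on an oxygen on an aromatic ring, gives a step that the two limits leave unreadable from compound 1 to compound 2, and neither end of that pair carries a readable number. Among the compounds with values here, compound 3 differs from compound 1 in more than one place and no step is drawn between them; its value is the only number in the set.

The unmeasured compound 4 `Cc1ccc(S(=O)(=O)Oc2ccc3c(c2C)[C@H](Cn2cc(-c4ccccn4)nn2)[C@@]24CC(=O)[C@@](C)(CC[C@@H]32)C4)cc1` differs from compound 1 as follows: pyridin-2-yl in place of 4-(trifluoromethyl)phenyl on an aromatic carbon. Within the data shown here, no measured step touches the group on the five-membered aromatic ring with 3 nitrogen, so nothing in the set fixes the direction or size of this change in this assay. Among the measured compounds shown here, the only anchor is that compound 1 sits at the limit. Expected here is a step that the limit leaves unreadable from compound 1 to compound 4. Compound 4 is therefore expected at 25000 nM, within 8000 nM to 80000 nM, with a real chance that only a limit is reported again.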

Compound 4, half-maximal inhibitory concentration: > 20000 nM
Compound 4: only a limit was reported; the forecaster's own chance of this, stated with the estimate: 70%; the middle value does not contradict the limit.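

In this assay compound 4 gives > 20000 nM, a limit of the assay. Compound 1 also carries only a limit, so no step can be read between compound 1 and compound 4. The compounds shown leave open how pyridin-2-yl and 4-(trifluoromethyl)phenyl on the five-membered aromatic ring with 3 nitrogen compare on the shared core.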